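The source may hold more compounds than are shown below. What is called first, only, known or untested is meant among the compounds shown, and "the series" means these compounds.

Among the compounds with values here, compound 3 `CC(C)=CC[C@@H](OCC(C)O)C1=CC(=O)c2c(O)ccc(O)c2C1=O` sits second highest of the three numbers so far in a functional assay on DU-145 cells (Homo sapiens) for cytotoxicity, read by MTT assay (a higher number here means a weaker inhibitor, a lower number a stronger inhibitor), giving 16100 nM. Its nearest neighbour is compound 2 `CC(C)=CC[C@@H](OCCO)C1=CC(=O)c2c(O)ccc(O)c2C1=O`, which gives 9900 nM; the step of a 1.6-fold higher number from compound 2 to compound 3 (0.21 log units; within the scatter) is within the scatter. The furthest is compound 1 `CCCCC(O)CC(=O)O[C@H](CC=C(C)C)C1=CC(=O)c2c(O)ccc(O)c2C1=O`, which gives 45300 nM; the step of a 2.8-fold lower number from compound 1 to compound 3 (0.45 log units; beyond the scatter) is beyond the scatter, as is a 4.6-fold lower number from compound 1 to compound 2 (0.66 log units; beyond the scatter).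

Compound 4 `CCC(O)CO[C@H](CC=C(C)C)C1=CC(=O)c2c(O)ccc(O)c2C1=O` is the next member in this direction: methyl in place of hydrogen on a saturated chain carbon, two bonds along the chain from an oxygen on a saturated carbon. Within the data shown here, the only measured step that bears on this kind of change is the one from compound 2 to compound 3, where a methyl in place of hydrogen on the chain moved the number a 1.6-fold higher number from compound 2 to compound 3 (0.21 log units; within the scatter), within the scatter. A second methyl one bond further along the same chain is therefore not expected to give a step beyond the scatter in this assay , with the direction left open. The step from compound 3 to compound 4 is expected to be a 1.1-fold higher number from compound 3 to compound 4 (0.05 log units; within the scatter). Compound 4 is estimated at 18000 nM, with a range from 8000 nM to 40000 nM.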

Compound 4, half-maximal inhibitory concentration: 16400 nM
The estimate for compound 4 lay 1.1-fold (0.04 log units) above the measured number; the range from low to high includes it.
By their numbers in this assay, from the lowest: compounds 2, 3 and 4 (each within the scatter of the next); then compound 1.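

Going from 2-hydroxypropyl to 2-hydroxybutyl at this position adds nothing readable in this assay, with a 1.0-fold higher number from compound 3 to compound 4 (0.01 log units; within the scatter), and ethyl in place of hydrogen on the same chain carbon also stays within the scatter, at a 1.7-fold higher number from compound 2 to compound 4 (0.22 log units; within the scatter), so the chain tolerates a methyl or an ethyl here without a measurable shift. The separation from the (2-hydroxyhexyl)carbonyl compound now holds for a third hydroxyalkyl chain, with a 2.8-fold lower number from compound 1 to compound 4 (0.44 log units; beyond the scatter) still beyond the scatter. No supporting evidence accounts for this flat response.

Compound 1 differs from the others in both its carbonyl and its chain length, so the two contributions cannot be separated. Going by these compounds, how a 2-hydroxyhexyl chain without the carbonyl, or an amine in place of the hydroxyl on this chain, would read remains open.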